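From compound 3 to compound 4: one group swapped

A few compounds are considered here, and "the series" means these few. Any claim that something is new, unique, unknown or untested is made for them only; others in the source may bear on it.

In a physicochemical assay for solubility, read by turbidimetry, measured as kinetic solubility, at pH 6.8 (a higher number here means a more soluble compound, a lower number a less soluble compound), three compounds that share one core have been measured so far. Compound 1 (`COc1ccc(F)cc1N1C(=O)CSC1c1cccc(C(=O)NCCCCc2ccccc2)c1`) gives 10000 nM there. Compound 2 (`O=C(NCCCCc1ccccc1)c1cccc(C2SCC(=O)N2c2ccccn2)c1`) gives 20000 nM and compound 3 (`O=C(NCCCCc1ccccc1)c1cccc(C2SCC(=O)N2c2ccccc2F)c1`) gives 20000 nM as well, so compound 3 stands level with compound 2 and within the scatter of compound 1.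

The change to compound 4 (`CC(F)(F)c1cccc(N2C(=O)CSC2c2cccc(C(=O)NCCCCc3ccccc3)c2)c1`) is a group of 10 heavy atoms (8 carbon, 2 fluorine; one six-membered aromatic ring of carbon only) in place of a group of 7 heavy atoms (6 carbon, 1 fluorine; one six-membered aromatic ring of carbon only), on an amide-type nitrogen in a ring and the rest of the molecule stays the same. Three measured swaps at that same nitrogen bear on it: a 2.0-fold higher number from compound 1 to compound 2 (0.30 log units; within the scatter) then a 2.0-fold higher number from compound 1 to compound 3 (0.30 log units; within the scatter) and finally no change at the digits printed from compound 2 to compound 3 (within the scatter) in turn. All of them stay small, although none of these compounds carries the entering group, so the evidence is indirect. In this assay no step beyond the scatter is therefore expected. The estimated step is a 1.4-fold lower number from compound 3 to compound 4 (0.15 log units; within the scatter) at most roughly. Compound 4 is expected near 14000 nM with an estimated range of 6000 nM to 30000 nM for now.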

Compound 4, solubility: 10000 nM
Beside the measured number, compound 4's estimate is 1.4-fold (0.15 log units) above it; the measured number falls inside the stated range.
By their numbers in this assay, from the lowest: compounds 1, 4, 2 and 3 (each within the scatter of the next).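

In this assay the group entering at this amide-type nitrogen in a ring is larger than any of the three earlier groups, yet the steps stay small: a 2.0-fold lower number from compound 3 to compound 4 (0.30 log units; within the scatter), a 2.0-fold lower number from compound 2 to compound 4 (0.30 log units; within the scatter) and no change at the digits printed from compound 1 to compound 4 (within the scatter). Across these four compounds, then, no step at this nitrogen goes beyond the scatter, and a group with two fluorine atoms and extra carbon fits that picture as well. No measurement offered here gives a reason for these numbers.

From the compounds shown here alone, all four groups at this nitrogen contain a six-membered aromatic ring, so it remains open whether an amine or a carboxylic acid on that ring would produce a step beyond the scatter. Going by these compounds, whether a shorter chain on the amide of the shared core would do so is also open.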